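Swapping the aryl group in a hexafluoro-carbinol pyridine series

This account rests on a few compounds, and the source may have more. Where it says the series, first, only, none or still open, it means among the compounds named here.

Measured compounds:
compound 1 `CCn1cc(-c2cc(C(O)(C(F)(F)F)C(F)(F)F)cnc2N2CCN(S(=O)(=O)c3ccc(N)nc3)CC2)cn1` gives 194 mL.min-1.g-1 in an ADME assay (liver) for metabolic stability, with Liver microsome (Rattus norvegicus) as the target, using microsomes and NADPH, with a stated time of 30 min, tested at 1 uM; on this read-out lower numbers stand for slow clearance and higher numbers for fast clearance
compound 2 `CS(=O)(=O)Nc1cccc(-c2cc(C(O)(C(F)(F)F)C(F)(F)F)cnc2N2CCN(S(=O)(=O)c3ccc(N)nc3)CC2)c1` gives 81 mL.min-1.g-1 in this assay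

Among the compounds with values here, compound 2 has the lower of the two numbers in this assay, and the one measured step, a 2.4-fold lower number from compound 1 to compound 2 (0.38 log units; beyond the scatter), sets it apart from compound 1. Compound 3 `Nc1ccc(S(=O)(=O)N2CCN(c3ncc(C(O)(C(F)(F)F)C(F)(F)F)cc3-c3ccc4c(c3)CC(=O)N4)CC2)cn1` carries a group of 10 heavy atoms (8 carbon, 1 nitrogen, 1 oxygen; one five-membered non-aromatic ring with 1 hetero atom, one six-membered aromatic ring of carbon only) in place of a group of 11 heavy atoms (7 carbon, 1 nitrogen, 2 oxygen, 1 sulfur; one six-membered aromatic ring of carbon only), on an aromatic carbon. Within the data shown here, no measured step bears directly on this change; the only comparison shows that the aryl group alters the read-out modestly. Compound 3 is expected to give 100 mL.min-1.g-1, with a range from 45 mL.min-1.g-1 to 220 mL.min-1.g-1. The expected step of a 1.2-fold higher number from compound 2 to compound 3 (0.09 log units; within the scatter) is therefore small and within the scatter.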

Compound 3, intrinsic clearance in microsomes: 119 mL.min-1.g-1
For compound 3 the middle estimate is 1.2-fold (0.08 log units) below the measured one; low and high end bracket the measured number.
By their numbers in this assay, from the lowest: compounds 2, 3 and 1 (each within the scatter of the next, the first and the last beyond it).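

In this assay, the group with a five-membered non-aromatic ring with 1 hetero atom cannot be told apart from either earlier group at this aromatic carbon (a 1.5-fold higher number from compound 2 to compound 3 (0.17 log units; within the scatter); a 1.6-fold lower number from compound 1 to compound 3 (0.21 log units; within the scatter)). Compound 3 thus lies within the scatter of both compound 1 and compound 2, although those two are separated by a step beyond it (a 2.4-fold lower number from compound 1 to compound 2 (0.38 log units; beyond the scatter)). Nothing available explains these numbers. From the compounds shown here alone, whether a carboxylic acid or an amine on the phenyl ring at this position would give a step beyond the scatter remains open.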